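Hydrazone Series on Prostate Cancer Cells: Estimating a Bromo Analogue

A few compounds are considered here, and "the series" means these few. Any claim that something is new, unique, unknown or untested is made for them only; others in the source may bear on it.

Measured so far:
compound 1 `Cc1c(C(=O)N/N=C\c2ccc(C(F)(F)F)cc2)oc2cccc(O)c12`: >= 40000 nM
compound 2 `Cc1c(C(=O)N/N=C\c2ccncc2)oc2cccc(O)c12`: >= 40000 nM
compound 3 `Cc1c(C(=O)N/N=C\c2cc(Cl)cc(Cl)c2O)oc2cccc(O)c12`: 9590 nM

All three share one core and differ only in the aromatic group attached to the carbon with a double bond to nitrogen. In a functional assay on PC-3 cells (Homo sapiens) for inhibition (on this read-out lower numbers stand for stronger inhibition and higher numbers for weaker inhibition), compound 1 reaches only a limit of the assay, >= 40000 nM. Compound 2 likewise stops at a limit in this assay, >= 40000 nM. Going by the values given here, compound 3 is the only one that gives a number in this assay, 9590 nM. Compound 2 therefore stands at the limit of >= 40000 nM in this assay, at which 2 of the 3 values shown sit, together with compound 1, and no numerical value is known for it.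

The unmeasured compound 4 `Cc1c(C(=O)N/N=C\c2cccc(Br)c2O)oc2cccc(O)c12` arises from compound 2 through (3-bromo-2-hydroxyphenyl in place of pyridin-4-yl on a carbon with a double bond to nitrogen). Among the compounds with values here, the group that enters resembles the group of compound 3, which is the one compound here that gives a number. The step in this assay is expected to run toward stronger inhibition, and an estimate of an at least 2.6-fold lower number from compound 2 to compound 4 (0.42 log units; beyond the scatter) is beyond the usual scatter. Compound 4 is expected to give about 15000 nM in this assay, with a range from 5000 nM to 40000 nM.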

Compound 4, half-maximal inhibitory concentration: 16600 nM
Compound 4: the middle estimate sits 1.1-fold (0.04 log units) below what was measured; measured number inside the range.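

In this assay, the group on the carbon with a double bond to nitrogen can move the read-out off the limit of the assay: putting 3-bromo-2-hydroxyphenyl in place of pyridin-4-yl gives an at least 2.4-fold lower number from compound 2 to compound 4 (0.38 log units; beyond the scatter). That size is only a lower bound on the step, because compound 2 has a limit and not a number: the limit of >= 40000 nM in this assay, at which 2 of the 4 values shown sit. Compound 3, at 9590 nM, and compound 4, at 16600 nM, are now the only two of the four that give a number, and both carry a hydroxyl and halogen on a carbon-only aromatic ring, whereas compound 1 and compound 2 have no hydroxyl on that ring, so none of the four goes against this link.

The step swaps the ring and adds the hydroxyl and the bromine all at once, so the compounds shown cannot say which of these changes matters, a question that plain 2-hydroxyphenyl and 3-bromophenyl would help to separate. On these data alone, it also stays open whether the hydroxyl can give way to a methoxy or an amine, and whether the bromine can give way to a methyl or a nitrile.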